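Des-fluoro analogue of compound 3 in the rat reductase assay

The source may hold more compounds than are shown below. What is called first, only, known or untested is meant among the compounds shown, and "the series" means these compounds.

Measured so far:
compound 1, `COc1cc(Cc2ccc(N)nc2N)cc(OC)c1O`, about 10000000 nM
compound 2, `CCc1cc(Cc2ccc(N)nc2N)cc(CC)c1O`, about 40000000 nM
compound 3, `COc1cc(Cc2cnc(N)c(F)c2N)cc(OC)c1O`, about 35000000 nM

All three numbers come from an assay for inhibition of Dihydrofolate reductase (Rattus norvegicus) (a lower number here means a stronger inhibitor, a higher number a weaker inhibitor), and all three sit at the weak end of the scale. Compound 3 holds the second highest number of the three. Its nearest neighbour is compound 2, whose number lies within the scatter of that of compound 3, so no order between the two can be claimed. Among the measured compounds shown here, its furthest neighbour is compound 1, whose lower number does lie beyond the scatter, but compounds 1 and 3 differ in more than one place, so the pair gives only the two values and no single step.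

Compound 4 is `COc1cc(Cc2cnc(N)cc2N)cc(OC)c1O`. It differs from compound 3 by one change: hydrogen in place of fluoro on an aromatic carbon. For the measured compounds named here, no measured pair in this set isolates that change, so there is nothing to lean on except the three weak numbers and the size of the change, which removes a single heavy atom. With no other guide, the expectation is that the step in this assay from compound 3 to compound 4 stays within the scatter, a 1.4-fold lower number from compound 3 to compound 4 (0.15 log units; within the scatter), in either direction.

On that basis compound 4 is estimated at 25000000 nM, with a plausible range from 6000000 nM to 100000000 nM.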

Compound 4, half-maximal inhibitory concentration: about 10000000 nM
Estimate against measurement, compound 4: 2.5-fold (0.40 log units) above, and the stated range covers the measured number.
By their numbers in this assay, from the lowest: compounds 1 and 4 (each within the scatter of the next); then compounds 3 and 2 (each within the scatter of the next).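

In this assay, among the compounds shown here, a 3.5-fold lower number from compound 3 to compound 4 (0.54 log units; beyond the scatter) is the first step that isolates a single change, and it shows that this aromatic carbon, ortho to two amino groups and two atoms from the ring nitrogen, is sensitive to the exchange of fluoro for hydrogen. The direction is also now defined: the hydrogen-bearing compound 4, at about 10000000 nM, has the lower number, so fluoro at this place brings no gain in this assay, although the step is modest, rests on one pair and sits at the weak end of the scale. Nothing available on the compounds accounts for the size or direction of this step.

As far as these compounds go, it remains open whether the step is particular to fluoro or whether chloro, methyl or methoxy on the same aromatic carbon would also give a higher number than hydrogen. Also open, from the compounds shown here alone, is whether the step carries over to a core bearing other ring substituents, such as the ethyl groups of compound 2, since one pair cannot show how general it is.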